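Succinimide in place of ureido on the pyrrole-type carbon

A few compounds are considered here, and "the series" means these few. Any claim that something is new, unique, unknown or untested is made for them only; others in the source may bear on it.

The series shares a sulfonamide-bearing aryl on the ring nitrogen of the core and is followed in a functional assay on MCF7 cells (Homo sapiens) for inhibition, read by sulforhodamine B assay, with a stated time of 24 h; a lower number here means a stronger inhibitor, a higher number a weaker inhibitor. Compound 1 `O=c1[nH]cnc2c1c(-c1ccccc1)cn2-c1ccc(S(=O)(=O)Nc2nccs2)cc1` gives 6210 nM. Compound 2 `N#Cc1c(-c2ccccc2)cn(-c2ccc(S(=O)(=O)Nc3nccs3)cc2)c1NC(N)=O` gives 8050 nM. Compound 3 `N#Cc1c(-c2ccccc2)cn(-c2ccc(S(=O)(=O)Nc3ccccn3)cc2)c1NC(N)=O` gives 7340 nM, the second highest of the three numbers; its nearest neighbour is compound 2 and its furthest is compound 1, both within the scatter, so no order among the three can be read. Within the data shown here, the one single-point step, a 1.1-fold lower number from compound 2 to compound 3 (0.04 log units; within the scatter), concerns the group on the sulfonamide nitrogen and lies within the scatter.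

Compound 4 `N#Cc1c(-c2ccccc2)cn(-c2ccc(S(=O)(=O)Nc3ccccn3)cc2)c1N1C(=O)CCC1=O` differs from compound 3 at the aromatic carbon: 2,5-dioxopyrrolidin-1-yl in place of ureido on an aromatic carbon. Among the measured compounds shown here, no measured step touches this position, and the step from compound 2 to compound 3 sits elsewhere in the molecule, so it gives no direct guide. For the measured compounds named here, with the three measured numbers all within the scatter of one another and no precedent for the exchange, the expectation for a 1.0-fold lower number from compound 3 to compound 4 (0.02 log units; within the scatter) is no step beyond the scatter, with a wide range to cover the unknown. The estimate for compound 4 in this assay is therefore 7000 nM, between 3000 nM and 17000 nM.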

Compound 4, half-maximal inhibitory concentration: 9930 nM
Beside the measured number, compound 4's estimate is 1.4-fold (0.15 log units) below it; measured number inside the range.
By their numbers in this assay, from the lowest: compounds 1, 3, 2 and 4 (each within the scatter of the next).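

In this assay, among these compounds, the exchange on an aromatic carbon of the five-membered aromatic ring gives a 1.4-fold higher number from compound 3 to compound 4 (0.13 log units; within the scatter) and so adds a first reading at this position, which the earlier step on the sulfonamide nitrogen did not touch. The two groups differ widely in what is counted: ureido has 4 heavy atoms and 2 hydrogen-bond donors, no ring and 1 hydrogen-bond acceptor, whereas 2,5-dioxopyrrolidin-1-yl has 7 heavy atoms, 0 hydrogen-bond donors, 2 hydrogen-bond acceptors and a five-membered non-aromatic ring, yet this single exchange does not move the number beyond the scatter. No supporting data bear on what lies behind this result.

Going by these compounds, a single pair cannot show whether this position is generally tolerant of change, and it remains open whether a primary amine, a carboxylic acid or a longer chain on the same carbon would produce a step beyond the scatter. On these data alone, it also remains open whether the same exchange would read alike with 1,3-thiazol-2-yl in place of pyridin-2-yl on the sulfonamide nitrogen.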